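The source may hold more compounds than are shown below. What is called first, only, known or untested is meant among the compounds shown, and "the series" means these compounds.

Measured compounds:
compound 1, `COc1ccc(-c2coc3cc(OCCCSC(=S)N4CCN(Cc5ccccc5)CC4)ccc3c2=O)cc1`, 43800 nM
compound 2, `COc1ccc(-c2coc3cc(OCCCSC(=S)N4CCOCC4)ccc3c2=O)cc1`, 49600 nM

Both numbers come from a functional assay on MGC-803 cells (Homo sapiens) for inhibition, read by MTT assay, with a stated time of 48 h; on this read-out lower numbers stand for stronger inhibition and higher numbers for weaker inhibition. In this assay compound 1 gives 43800 nM and compound 2 gives 49600 nM. Compound 1 has the lower of the two numbers, but the gap is within the usual scatter of repeated measurements, so the two compounds cannot be told apart; both inhibit the cells only weakly.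

Compound 3, `COc1ccc(-c2coc3cc(OCCCSC(=S)N4CCN(C)CC4)ccc3c2=O)cc1`, has not yet been measured. It differs from compound 1 in one place: hydrogen in place of phenyl on a saturated chain carbon bound to an amine nitrogen in a ring. Among the compounds with values here, no measured pair shows this kind of change, so the expectation rests on compound 1 alone. Given that compound 1 gives 43800 nM and compound 2, with a different ring in the same region, gives 49600 nM, the outcome is expected to stay close to these values, with a small step toward a higher number, if any. For compound 3 the estimated value is 55000 nM, with a range from 22000 nM to 140000 nM. The expected step is a 1.3-fold higher number from compound 1 to compound 3 (0.10 log units; within the scatter).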

Compound 3, half-maximal inhibitory concentration: 21900 nM
Compound 3: the middle estimate sits 2.5-fold (0.40 log units) above what was measured; measured number outside the range, below it.
By their numbers in this assay, from the lowest: compounds 3, 1 and 2 (each within the scatter of the next, the first and the last beyond it).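

In this assay, going from benzyl to methyl gives a 2.0-fold lower number from compound 1 to compound 3 (0.30 log units; within the scatter), so the phenyl group is not needed for the inhibition seen in these cells. Exchanging morpholin-4-yl for 4-methylpiperazin-1-yl on the thiocarbonyl carbon gives a 2.3-fold lower number from compound 2 to compound 3 (0.36 log units; beyond the scatter), a modest step and the only one here beyond the scatter, and compound 3 still inhibits the cells only weakly. Nothing available explains either step.

The compounds shown leave open whether a larger difference would appear with another group on the ring amine nitrogen, such as an ethyl group or a chain ending in a carboxylic acid. They also leave open whether an amine-bearing ring other than these two, such as piperidine, would give a lower number.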